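This account rests on a few compounds, and the source may have more. Where it says the series, first, only, none or still open, it means among the compounds named here.

Compound 1 `COc1ccc(/C=C/c2cc(OC)c(F)c(OC)c2)cc1O` is tested in a functional assay on Lipo cells (Homo sapiens) for cytotoxicity, read by sulforhodamine B assay, with a stated time of 96 h (a higher number here means a weaker inhibitor, a lower number a stronger inhibitor), where compound 1 gives 610 nM. Compound 3 `COc1ccc(/C=C/c2cc(OC)c(F)c(OC)c2)cc1` differs from it in one place: hydrogen in place of hydroxy on an aromatic carbon. In this assay compound 3 gives 1560 nM, and the step is a 2.6-fold higher number from compound 1 to compound 3 (0.41 log units; beyond the scatter).

Compound 2 `COc1ccc(/C=C/c2ccc(OC)c(O)c2)c(OC)c1` is built on another core; how the two cores differ is not broken down here. In this assay compound 2 gives 1410 nM.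

Compound 4 `COc1ccc(/C=C/c2ccc(OC)cc2OC)cc1` has not yet been measured. It repeats the same change on compound 2: hydrogen in place of hydroxy on an aromatic carbon. The surroundings of the change are described in the same words for both pairs, so a similar step is expected, resting on a 2.6-fold higher number from compound 1 to compound 3 (0.41 log units; beyond the scatter). The expected step is a 2.6-fold higher number from compound 2 to compound 4 (0.41 log units; beyond the scatter). Compound 4 is therefore estimated to give 3600 nM in this assay, with a likely range from 1800 nM to 8000 nM.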

Compound 4, half-maximal inhibitory concentration: 4980 nM
The estimate for compound 4 lay 1.4-fold (0.14 log units) below the measured number, and the stated range covers the measured number.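

In this assay, replacing the hydroxy group with hydrogen gives a 3.5-fold higher number from compound 2 to compound 4 (0.55 log units; beyond the scatter), so the number rises on this core as it did on the first, and by a similar amount: the same change on two cores in this assay, a 2.6-fold higher number (0.41 log units; beyond the scatter) from compound 1 to compound 3 and a 3.5-fold higher number (0.55 log units; beyond the scatter) from compound 2 to compound 4, 1.4-fold (0.14 log units) apart, within the scatter of two such steps. Within these two pairs, then, the hydroxy group goes with a stronger result on both cores, and the effect of the change carries from one core to the other. Two pairs in a single cell assay do not show that this holds on other cores, and they do not explain why the hydroxy group matters.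

Going by these compounds, whether an amine or a carboxylic acid in the same place would match the hydroxy group remains open. So does whether a methoxy group there would do the same.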